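Methyl-to-hydrogen change on an aromatic oxygen in a flavonolignan series

The source may report more compounds than this note shows. Statements on the series, on what has been measured and on what is new or still open speak of the compounds shown alone.

Of the compounds shown here, three have been measured in a functional assay on HUVEC cells (Homo sapiens) for antiproliferative activity, read by MTT assay, with a stated time of 72 h; a lower number here means a stronger inhibitor, a higher number a weaker inhibitor. Compound 1 `COc1cc(C2Oc3cc(-c4oc5cc(O)cc(O)c5c(=O)c4OC)ccc3OC2CO)ccc1O` gives 4900 nM in this assay. Compound 2 `COc1cc(O)c2c(=O)c(OC)c(-c3ccc4c(c3)OC(c3ccc(O)c(OC)c3)C(CO)O4)oc2c1` gives 8300 nM in this assay. Compound 3 `COCC1Oc2ccc(-c3oc4cc(OC)cc(O)c4c(=O)c3O)cc2OC1c1ccc(O)c(OC)c1` gives 4000 nM in this assay.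

Compound 2 and compound 1 differ in one place: hydrogen in place of methyl on an oxygen on an aromatic ring. This change made a step of a 1.7-fold lower number from compound 2 to compound 1 (0.23 log units; within the scatter), which is within the scatter, so no direction can be read from it.

Compound 3 and compound 2 are built from the same atoms joined differently; the difference between the two cores is not broken down here. Compound 3 stands at the lowest of the three numbers, with compound 1 within the scatter of it and compound 2 beyond it.

Compound 4 `COCC1Oc2ccc(-c3oc4cc(O)cc(O)c4c(=O)c3O)cc2OC1c1ccc(O)c(OC)c1` has not yet been measured in this assay. It differs from compound 3 in one place: hydrogen in place of methyl on an oxygen on an aromatic ring. The place of this change is described in the same words as the change from compound 2 to compound 1, so it is the same change. For the measured compounds named here, on that basis the step from compound 3 to compound 4 is expected to be small, with a step of about a 1.3-fold lower number from compound 3 to compound 4 (0.10 log units; within the scatter), resting on the size of the single earlier step of a 1.7-fold lower number from compound 2 to compound 1 (0.23 log units; within the scatter). Compound 4 is therefore expected to give about 3200 nM in this assay, with a range of 1300 nM to 8000 nM expected to cover most repeat measurements.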

Compound 4, half-maximal inhibitory concentration: 5300 nM
For compound 4 the middle estimate is 1.7-fold (0.22 log units) below the measured one; measured number inside the range.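

On the second core, the methoxy to hydroxy change on an oxygen on an aromatic ring gives a 1.3-fold higher number from compound 3 to compound 4 (0.12 log units; within the scatter) in this assay, so this step, like the earlier one, shows no direction of its own. Set beside each other, the two steps cannot be told apart: the same change on two cores in this assay, a 1.7-fold lower number (0.23 log units; within the scatter) from compound 2 to compound 1 and a 1.3-fold higher number (0.12 log units; within the scatter) from compound 3 to compound 4, 2.2-fold (0.35 log units) apart, within the scatter of two such steps

For the compounds shown here, for carrying the change between these two cores, this means only that no step beyond the scatter appears on either one; it does not show that the change has a fixed size or direction, and the lower and higher wording of the two steps should not be read as a reversal between cores.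

The compounds shown carry only methyl or hydrogen on the aromatic oxygen, so it stays open whether a longer chain or an acetyl group there, or an amine in place of that hydroxy group, would give a step beyond the scatter. Going by these compounds alone, with only two small steps on two cores, it also stays open whether the same change would remain this small on any further core of the series.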